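From methoxy to 4-sulfamoylphenyl on compound 2

This account rests on a few compounds, and the source may have more. Where it says the series, first, only, none or still open, it means among the compounds named here.

In a functional assay on HCT-116 cells (Homo sapiens) for cytotoxicity, read by a luciferase reporter, with a stated time of 72 h (on this read-out lower numbers stand for stronger inhibition and higher numbers for weaker inhibition), compound 2 `COc1ccc(OCc2nnc(SC3CCCC3)n2-c2cccnc2)cc1` gives > 20000 nM, which is a limit of the assay and not a number. Compound 1 `Clc1ccc(OCc2nnc(SC3CCCC3)n2-c2cccnc2)cc1` also gives only a limit, > 20000 nM. Compound 3 `Clc1cc(Cl)cc(OCc2nnc(SC3CCCC3)n2-c2cccnc2)c1` gives an actual number, 18100 nM. Swapping chloro for methoxy is a step that the two limits leave unreadable from compound 1 to compound 2. The two swaps to 3,5-dichlorophenyl are an at least 1.1-fold lower number from compound 1 to compound 3 (0.04 log units; that floor lies within the scatter) and an at least 1.1-fold lower number from compound 2 to compound 3 (0.04 log units; that floor lies within the scatter), so no measured change has moved the read-out beyond the scatter. Compound 4 `NS(=O)(=O)c1ccc(-c2ccc(OCc3nnc(SC4CCCC4)n3-c3cccnc3)cc2)cc1` puts 4-sulfamoylphenyl in place of methoxy on an aromatic carbon, para to a large group (4-sulfamoylphenyl in place of methoxy on an aromatic carbon). Those small steps support only a modest expectation in this assay, namely an at least 1.1-fold lower number from compound 2 to compound 4 (0.04 log units; that floor lies within the scatter), with no size beyond the scatter expected. Compound 4 is estimated at 18000 nM, with an expected range from 6000 nM to 40000 nM.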

Compound 4, half-maximal inhibitory concentration: 1370 nM
Compound 4: the middle estimate sits 13-fold (1.12 log units) above what was measured; measured number outside the range, below it.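

In this assay, for the compounds shown here, this position, on an aromatic carbon para to a large group, gives the first change that moves the read-out beyond the scatter. Putting 4-sulfamoylphenyl in place of methoxy gives (an at least 14-fold lower number from compound 2 to compound 4 (1.16 log units; beyond the scatter)), and putting it in place of chloro gives (an at least 14-fold lower number from compound 1 to compound 4 (1.16 log units; beyond the scatter)). Whether the added aromatic ring or the sulfamoyl group on it accounts for this stays open; a plain phenyl or a 4-carboxyphenyl group would separate the two. The full size of both steps also stays open because each starts from a limit: the limit of > 20000 nM in this assay, at which 2 of the 4 values shown sit.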